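A few compounds are considered here, and "the series" means these few. Any claim that something is new, unique, unknown or untested is made for them only; others in the source may bear on it.

Measured so far in a functional assay on MDA-MB-468 cells (Homo sapiens) for inhibition, read by sulforhodamine B assay, with a stated time of 48 h; a lower number here means that less compound is tolerated, a higher number that more compound is tolerated:
compound 1 `COc1cc(-c2nn(-c3cccc(NC(=O)Nc4ccc(Cl)c(Cl)c4)c3)cc2-c2ccncc2)ccc1Cl`: > 50000 nM
compound 2 `COc1cc(-c2nn(-c3cccc(NC(=O)c4ccc(Cl)c(C(F)(F)F)c4)c3)cc2-c2ccncc2)ccc1Cl`: > 32500 nM

Both figures are limits of this assay, not numbers. Compound 2 stands at the limit of > 32500 nM in this assay, at which 1 of the 2 values shown sits, so no numerical value places it. Compound 3 `COc1cc(-c2nn(-c3cccc(NC(=O)Nc4ccc(Cl)c(C(F)(F)F)c4)c3)cc2-c2ccncc2)ccc1Cl` differs from compound 2 by (4-chloro-3-(trifluoromethyl)phenyl)amino in place of 4-chloro-3-(trifluoromethyl)phenyl on a carbonyl carbon. Among the compounds with values here, the one measured step, a step that the two limits leave unreadable from compound 1 to compound 2, runs between two limits and has no readable size. Compound 1, which likewise carries an amino-linked group on the carbonyl carbon, sits at the limit of > 50000 nM in this assay, at which 1 of the 2 values shown sits. No step beyond the scatter is therefore expected. Compound 3 is expected at 50000 nM, with a range from 20000 nM to 120000 nM. The expected step is a step that the limit leaves unreadable from compound 2 to compound 3, most likely again only a limit.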

Compound 3, concentration lethal to 50% of the cells: > 32500 nM
Compound 3: a limit, no number (the forecaster's own chance of this, stated with the estimate: 85%); the middle value lies beyond the limit too.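

Compound 3 gives > 32500 nM, which is a limit and not a number. Within the data shown here, compound 1 and compound 2 also stand at limits, so no step among the three can be read. The compounds shown leave open whether either change alters the read-out in this assay.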